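Compound 1 to Compound 3: an Expected Solubility Read-out

A few compounds are considered here, and "the series" means these few. Any claim that something is new, unique, unknown or untested is made for them only; others in the source may bear on it.

Measured so far:
compound 1, `O=C(O)c1ccc(C(=O)/C(=C\c2ccc([N+](=O)[O-])c(F)c2)SCc2ccc(Br)cc2)cc1`: < 1000 ug/mL
compound 2, `COC(=O)c1ccc(C(=O)/C(=C\c2ccc(F)c([N+](=O)[O-])c2)SCc2ccc(Br)cc2)cc1`: < 1000 ug/mL

In a physicochemical assay for solubility (on this read-out higher numbers stand for higher solubility and lower numbers for lower solubility), compound 1 gives < 1000 ug/mL, which is a limit of the assay rather than a number. Compound 2 in this assay gives < 1000 ug/mL, again only a limit. The shared reading is the limit of < 1000 ug/mL in this assay, at which 2 of the 2 values shown sit. Compound 3, `COc1cc(/C=C(/SCc2ccc(Br)cc2)C(=O)c2ccc(C(=O)O)cc2)ccc1F`, has not yet been measured; it differs from compound 1 by 4-fluoro-3-methoxyphenyl in place of 3-fluoro-4-nitrophenyl on a double-bonded chain carbon bound to a double-bonded chain carbon. Among the compounds with values here, no step between two measured compounds exists here, so the expected change in this assay is taken as none beyond the usual scatter. Compound 3 is therefore estimated at 300 ug/mL, with a range from 50 ug/mL to 1000 ug/mL, implying an expected step that the limit leaves unreadable from compound 1 to compound 3.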

Compound 3, solubility: < 1000 ug/mL
Compound 3: a limit, no number; the forecaster's own chance of this, stated with the estimate: 70%; the middle value does not contradict the limit.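

Within the data shown here, compound 1 and compound 3 both stand as limits in this assay and no step between them can be read, with the shared reading as follows: the limit of < 1000 ug/mL in this assay, at which 3 of the 3 values shown sit. The compounds shown leave open how the 4-fluoro-3-methoxyphenyl and 3-fluoro-4-nitrophenyl compounds compare as actual numbers.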